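The compounds below may be only part of what the source reports. "The series", "measured", "known", "first", "only" and "open" are said of these compounds alone.

In an ADME assay on L02 cells (Homo sapiens) for inhibition, read by CCK-8 assay, with a stated time of 48 h (on this read-out higher numbers stand for weaker inhibition of growth and lower numbers for stronger inhibition of growth), three compounds sharing one core have been measured so far. Compound 1 `Cc1ccccc1Nc1nc(Nc2cccnc2)ncc1Cl` gives 22900 nM. Compound 2 `Cc1ccc(Nc2ncc(Cl)c(Nc3ccccc3C)n2)cc1` reads > 100000 nM, which is a limit of the assay and not a number. Compound 3 `Cc1ccccc1Nc1nc(NCc2ccccc2)ncc1Cl` reads > 100000 nM, which is likewise a limit. That places compound 3 at the limit of > 100000 nM in this assay, at which 2 of the 3 values shown sit, so its true position on the scale is not known.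

Compound 4 `Cc1ccccc1Nc1nc(Nc2ccccn2)ncc1Cl` has not yet been measured in this assay. It carries pyridin-2-yl in place of benzyl on a nitrogen on an aromatic ring.

Among the compounds with values here, two measured steps bear most directly on this change. Replacing pyridin-3-yl with benzyl at the same place gave an at least 4.3-fold higher number from compound 1 to compound 3 (0.64 log units; beyond the scatter), and replacing it with 4-methylphenyl gave an at least 4.3-fold higher number from compound 1 to compound 2 (0.64 log units; beyond the scatter). Both are beyond the scatter, although each is only a minimum size. The remaining comparison is a step that the two limits leave unreadable from compound 2 to compound 3, which adds nothing.

Of the three groups tried, only the pyridin-3-yl of compound 1 has given a number, at 22900 nM, and compound 4 also bears a pyridine ring. A step towards stronger inhibition of growth is therefore expected, estimated as an at least 2.8-fold lower number from compound 3 to compound 4 (0.45 log units; beyond the scatter). Compound 4 is expected to read 35000 nM, with an estimated range from 12000 nM to 95000 nM.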

Compound 4, concentration for 50% growth inhibition: 6150 nM
Compound 4: middle estimate off by 5.7-fold (0.76 log units), on the high side; the measured number lies below the stated range.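

In this assay, compound 4 now stands apart from all three earlier compounds, since each of its steps lies beyond the scatter: an at least 16-fold lower number from compound 3 to compound 4 (1.21 log units; beyond the scatter) and an at least 16-fold lower number from compound 2 to compound 4 (1.21 log units; beyond the scatter), both minimum sizes, as each starts from a limit. The new information is that the choice of pyridine also counts at this place on the nitrogen, not only the presence of a pyridine ring, with pyridin-2-yl in place of pyridin-3-yl giving a 3.7-fold lower number from compound 1 to compound 4 (0.57 log units; beyond the scatter). Among these four compounds, the two bearing a pyridine ring give numbers, and none goes against this, while the 4-methylphenyl of compound 2 and the benzyl of compound 3 leave only limits: the limit of > 100000 nM in this assay, at which 2 of the 4 values shown sit.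

Going by these compounds, the true positions of compound 2 and compound 3 remain unknown, and the step between them cannot be read. Also open, on these data alone, is whether pyridin-4-yl at this place, or an amine or a methyl group added to the pyridin-2-yl ring, would take the number lower still or bring it back towards the limit.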